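From Fluoro to Chloro on the Core of Compound 1

The source may report more compounds than this note shows. Statements on the series, on what has been measured and on what is new or still open speak of the compounds shown alone.

In an ADME assay on MT4 cells (Homo sapiens) for cytotoxicity, read by spectrophotometry, with a stated time of 5 days (a higher number here means that more compound is tolerated, a lower number that less compound is tolerated), compound 1 (`O=C1/C(=N\NC(=S)NO)c2cc(F)ccc2N1CN1CCN(c2ccc(Cl)cc2)CC1`) gives 194000 nM and compound 2 (`COc1ccc(N2CCN(CN3C(=O)/C(=N\NC(=S)NO)c4cc(F)ccc43)CC2)cc1`) gives 260000 nM, so the two stand level (a 1.3-fold higher number from compound 1 to compound 2 (0.13 log units; within the scatter)). Compound 3 (`O=C1/C(=N\NC(=S)NO)c2cc(Cl)ccc2N1CN1CCN(c2ccc(Cl)cc2)CC1`) has chloro in place of fluoro on an aromatic carbon of the shared core (chloro in place of fluoro on an aromatic carbon). Within the data shown here, the sole measured step, methoxy in place of chloro on an aromatic carbon, is a different change and offers only a rough guide. No step beyond the scatter is therefore expected in this assay, and the expected step is a 1.0-fold lower number from compound 1 to compound 3 (0.01 log units; within the scatter) and no larger. For compound 3 the estimate is 190000 nM with an expected range from 100000 nM to 340000 nM around it.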

Compound 3, half-maximal cytotoxic concentration: 268000 nM
Compound 3: the middle estimate sits 1.4-fold (0.15 log units) below what was measured; the range from low to high includes it.
By their numbers in this assay, from the lowest: compounds 1, 2 and 3 (each within the scatter of the next).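

In this assay, chloro in place of fluoro on an aromatic carbon of the shared core gives a 1.4-fold higher number from compound 1 to compound 3 (0.14 log units; within the scatter), so the two compounds stand level. The earlier step spoke only of methoxy in place of chloro at a different place, whereas this one shows that the position on the core takes either fluoro or chloro with no step beyond the scatter. Nothing available explains this result. The compounds shown leave open whether an amine, a carboxylic acid or a longer chain at this position would also stand level.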